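A few compounds are considered here, and "the series" means these few. Any claim that something is new, unique, unknown or untested is made for them only; others in the source may bear on it.

Of the compounds shown here, three sharing the same core have so far been measured in a physicochemical assay for lipophilicity, using the shake flask method, in phosphate buffer, measured as octanol-water partition, at pH 7.4; a higher number here means a more lipophilic compound, a lower number a more polar compound. Compound 1 `COc1cc(-c2cc(C(=O)O)c3ccccc3n2)ccc1OCC(=O)Nc1cccc(C)c1` gives 1.5, which places it second highest of the three numbers. Compound 2 `COc1cc(-c2cc(C(=O)O)c3ccccc3n2)ccc1OCC(=O)Nc1ccc(F)cc1` gives 1.1, and compound 3 `COc1cc(-c2cc(C(=O)O)c3ccccc3n2)ccc1OCC(=O)Nc1cccc(Cl)c1` gives 2.3. The step of a number 0.40 log units lower from compound 1 to compound 2 (beyond the scatter) is modest, the step of a number 0.80 log units higher from compound 1 to compound 3 (beyond the scatter) is also modest, while the step of a number 1.20 log units higher from compound 2 to compound 3 (beyond the scatter) is large.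

Compound 4 `COc1cc(-c2cc(C(=O)O)c3ccccc3n2)ccc1OCC(=O)Nc1ccc(Cl)cc1` has not yet been measured. It differs from compound 1 in one place: 4-chlorophenyl in place of 3-methylphenyl on an amide-type nitrogen. For the measured compounds named here, two measured steps bear on this change. Putting chloro in place of methyl on an aromatic carbon gave a number 0.80 log units higher from compound 1 to compound 3 (beyond the scatter), and going from 4-fluorophenyl to 3-chlorophenyl gave a number 1.20 log units higher from compound 2 to compound 3 (beyond the scatter). Going by the values given here, no measured compound carries a 4-chlorophenyl group, so the exact size of the step is uncertain, but a rise beyond the scatter in this assay is expected, in the same direction as both steps. The step from compound 1 to compound 4 is therefore estimated as a number 0.60 log units higher from compound 1 to compound 4 (beyond the scatter). Compound 4 is expected to give 2.1 in this assay, with a likely range from 1.6 to 2.6.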

Compound 4, distribution coefficient: 1.5
For compound 4 the middle estimate is 0.60 log units above the measured one; measured number below the stated range.
By their numbers in this assay, from the lowest: compound 2; then compounds 1 and 4 (each within the scatter of the next); then compound 3.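

In this assay the change to 4-chlorophenyl gives no change at the digits printed from compound 1 to compound 4 (within the scatter) and thereby shows that, at this amide-type nitrogen, a chloro group on the ring does not bring a rise wherever it stands. The two chlorophenyl groups hold the same atoms, yet 4-chlorophenyl in place of 3-chlorophenyl gives a number 0.80 log units lower from compound 3 to compound 4 (beyond the scatter) and so, among these compounds, the place of the chloro group on the ring matters and not just its presence. Between the 4-fluorophenyl and 4-chlorophenyl groups, chloro in place of fluoro gives a number 0.40 log units higher from compound 2 to compound 4 (beyond the scatter) and so the identity of the atom counts as well, though nothing measured here says why these numbers fall as they do.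

A 4-methylphenyl or a 3-fluorophenyl group would help show whether the number for compound 3 is particular to the 3-chlorophenyl group or is shared by other groups at that ring place. Also open, as far as these compounds go, is how this assay would respond to an amine on this ring, or to a longer chain between the amide-type nitrogen and the ring.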